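This account rests on a few compounds, and the source may have more. Where it says the series, first, only, none or still open, it means among the compounds named here.

Compound 1 `CO[C@H]1CC=C2CCN(C)[C@H]2C1` in an assay on HEK293 cells for antagonist activity at Neuronal acetylcholine receptor; alpha3/beta4 (Rattus norvegicus), read by FLIPR, using a membrane potential dye; a lower number here means a stronger inhibitor, a higher number a weaker inhibitor: > 300000 nM, a limit of the assay.
Compound 2 `CCO[C@H]1CC=C2CCN(C)[C@H]2C1` in this assay: > 300000 nM, a limit of the assay.
Compound 3 `COCCO[C@H]1CC=C2CCN(C)[C@H]2C1` in this assay: > 300000 nM, a limit of the assay.

Compound 3 carries a 2-methoxyethyl chain on an oxygen on a saturated carbon of the shared core. Where it stands is not a number but a limit: in this assay compound 3 reached > 300000 nM, meaning no inhibition strong enough to be measured was seen.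

All three measured compounds sit together at the limit of > 300000 nM in this assay, at which 3 of the 3 values shown sit. For that reason none of the steps between them can be read: a step that the two limits leave unreadable from compound 1 to compound 2, a step that the two limits leave unreadable from compound 1 to compound 3 and a step that the two limits leave unreadable from compound 2 to compound 3. Each of these steps changes the chain on the oxygen, so each bears on the change to compound 4, yet none gives a size or a direction.

Compound 4 `CN1CCC2=CC[C@H](O)C[C@@H]21` differs from compound 3 in one place: hydrogen in place of 2-methoxyethyl on an oxygen on a saturated carbon. With every step unreadable and every value at the limit, no step beyond the scatter in either direction can be expected. The expected step is a number no higher from compound 3 to compound 4 (the limit leaves the size open), which is essentially none. Compound 4 is therefore estimated at 300000 nM, with a range from 100000 nM to 1000000 nM, and most likely a limit again.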

Compound 4, half-maximal inhibitory concentration: > 300000 nM
Compound 4 gave a limit, no number (the forecaster's own chance of this, stated with the estimate: 85%); the middle value sits exactly at the limit.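

In this assay compound 4 gives > 300000 nM as a limit of the assay, not a number. Its steps from compound 1, compound 2 and compound 3 cannot be read, because all the compounds share one limit: the limit of > 300000 nM in this assay, at which 4 of the 4 values shown sit.

How strongly any of these compounds inhibits, and whether the chain on the oxygen matters at all, stays open.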